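Notes on the step from compound 2 to compound 4

A few compounds are considered here, and "the series" means these few. Any claim that something is new, unique, unknown or untested is made for them only; others in the source may bear on it.

Measured so far in an ADME assay (liver, Mus musculus) for metabolic stability, read by LC-MS, using microsomes, tested at 1 uM; on this read-out higher numbers stand for a longer-lived compound and lower numbers for a shorter-lived compound:
- Compound 1 (`CCN(CC)CCC/N=C(/N=c1\ccn(CCCN(CC)CC)c2cc(Cl)ccc12)c1cccnc1`): limit (> 1 h)
- Compound 2 (`CCN(CC)CCCCCN/C(C)=N\c1ccnc2cc(Cl)ccc12`): limit (> 1 h)
- Compound 3 (`CN(C)CCCN/C(=N\c1ccnc2cc(Cl)ccc12)c1ccc(Cl)cc1`): value (0.583 h)

Compound 2 is known only as a limit (> 1 h), not as a number. It stands with compound 1 at the top of the values shown (the limit of > 1 h in this assay, at which 2 of the 3 values shown sit).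

Compound 4 (`C/C(=N/c1ccnc2cc(Cl)ccc12)NCCCCN1CCCCC1`) differs from compound 2 as follows: piperidin-1-yl in place of (diethylamino)methyl on a saturated chain carbon, four bonds along the chain from an amine nitrogen. Piperidin-1-yl takes the place of (diethylamino)methyl on a saturated chain carbon, four bonds along the chain from an amine nitrogen.

Within the data shown here, no measured step covers this change, so no shift beyond the scatter is expected in this assay. The estimated step is a number no higher from compound 2 to compound 4 (the limit leaves the size open) in half-life. Compound 4 is estimated at 1 h with 0.45 h to 2.2 h as the expected range.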

Compound 4, half-life: > 1 h
Compound 4 was reported as a limit; the forecaster's own chance of this, stated with the estimate: 50%; the middle value lies on the limit itself.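

Compound 2 and compound 4 are both known only as limits in this assay, so no step can be read between them. As far as these compounds go, whether piperidin-1-yl in place of (diethylamino)methyl shifts half-life at all stays open.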